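A fluoro step from compound 1 to compound 3

The source may hold more compounds than are shown below. What is called first, only, known or untested is meant among the compounds shown, and "the series" means these compounds.

In a functional assay on CCRF-CEM cells (Homo sapiens) for inhibition (a lower number here means a stronger inhibitor, a higher number a weaker inhibitor), compound 1 (`Nc1ncnc2c1ncn2[C@@H]1O[C@@H](CO)C=C1F`) gives > 100000 nM, which is a limit of the assay and not a number. Compound 2 (`OC[C@H]1C=C(F)[C@H](n2cnc3c(O)ncnc32)O1`) gives > 100000 nM, which is also a limit. Among the measured compounds shown here, the only measured step is a step that the two limits leave unreadable from compound 1 to compound 2, so it supplies no size that could be carried over. What the data offer is the limit of > 100000 nM in this assay, at which 2 of the 2 values shown sit.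

Compound 3 (`Nc1nc(F)nc2c1ncn2[C@@H]1O[C@@H](CO)C=C1F`) has not yet been measured. It keeps the amino group of compound 1 and has fluoro in place of hydrogen on an aromatic carbon, between two ring nitrogen atoms and meta to an amino group: fluoro in place of hydrogen on an aromatic carbon. For the measured compounds named here, no measured compound shows this change, and both measured values stop at the same limit, so the expectation is weakly founded. Compound 3 is expected to remain a very weak inhibitor, quite possibly reported only as a limit again, with any readable shift toward stronger inhibition. The estimated change is an at least 1.4-fold lower number from compound 1 to compound 3 (0.15 log units; that floor lies within the scatter). For compound 3 the expected value is 70000 nM, with an estimated range from 15000 nM to 200000 nM.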

Compound 3, half-maximal inhibitory concentration: > 100000 nM
Compound 3 gave a limit, no number; the forecaster's own chance of this, stated with the estimate: 65%; middle value at least 1.4-fold (0.15 log units) away from the limit.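

In this assay compound 3 gives > 100000 nM, which is a limit and not a number. Compound 1 also stands at a limit, so the step between these two compounds cannot be read. The compounds shown leave open whether either change on the shared core has any effect on inhibition, as every value stops at one ceiling: the limit of > 100000 nM in this assay, at which 3 of the 3 values shown sit.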